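The source may report more compounds than this note shows. Statements on the series, on what has been measured and on what is new or still open speak of the compounds shown alone.

Working notes on the aorta series.

Compound 1 `CCO/C(O)=C1\C(COCCn2c(N)cnc2O)=NC(C)=C(C(=O)OC)C1c1ccccc1Cl` is the weaker of the two measured entries: in a functional assay (aorta) with Rattus norvegicus as the target (on this read-out lower numbers stand for stronger inhibition and higher numbers for weaker inhibition), compound 1 gives 158 nM, the highest number of the pair. Compound 2 `CCO/C(O)=C1\C(COCCn2ccnn2)=NC(C)=C(C(=O)OC)C1c1cccc(Cl)c1Cl` carries a different five-membered ring on the chain and a second chlorine on the phenyl ring; in this assay compound 2 gives 5.01 nM. The two compounds differ in more than one place, so the two values are recorded side by side without assigning the gap to either change.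

Compound 3 `CCO/C(O)=C1\C(COCCN2CC(=O)N(C)C2=O)=NC(C)=C(C(=O)OC)C1c1ccccc1Cl` keeps the shared core and the chloro-substituted phenyl ring of compound 1 and alters only the ring at the end of the chain: 3-methyl-2,4-dioxoimidazolidin-1-yl in place of 5-amino-2-hydroxy-1H-imidazol-1-yl on a saturated chain carbon, two bonds along the chain from an oxygen on a saturated carbon. Going by the values given here, no measured pair isolates this change, so the size of the step is open. Given compound 1 at 158 nM, the expectation is a modest step towards a lower number, of a size that may or may not clear the scatter: the step from compound 1 to compound 3 in this assay is estimated at a 1.6-fold lower number from compound 1 to compound 3 (0.20 log units; within the scatter). For compound 3 the value in this assay is estimated at 100 nM, with a range from 25 nM to 400 nM.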

Compound 3, half-maximal inhibitory concentration: 25.1 nM
Compound 3: the middle estimate sits 4.0-fold (0.60 log units) above what was measured; the measured number falls inside the stated range.
By their numbers in this assay, from the lowest: compound 2; then compound 3; then compound 1.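

With the shared core and the chloro-substituted phenyl ring held fixed, the ring at the end of the chain now has a readable effect of its own in this assay: a 6.3-fold lower number from compound 1 to compound 3 (0.80 log units; beyond the scatter), for the change on a saturated chain carbon, two bonds along the chain from an oxygen on a saturated carbon. The position therefore accepts a five-membered non-aromatic ring with 0 hydrogen-bond donors in place of a five-membered aromatic ring with 2, and the lower number goes with the 3-methyl-2,4-dioxoimidazolidin-1-yl group, though aromaticity, donor count and acceptor count all change in this one step and it cannot separate them. No measurement is available that would explain the step.

Steps involving compound 2 cannot be read, since it differs from compound 1 and compound 3 in more than one place, so the separate contributions of its second chlorine and its ring on the chain remain unknown. Also open, going by these compounds, is whether a carboxylic acid or a simple amine at the chain end, or a longer chain carrying the 3-methyl-2,4-dioxoimidazolidin-1-yl group, would keep a number of this size.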